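This account rests on a few compounds, and the source may have more. Where it says the series, first, only, none or still open, it means among the compounds named here.

In a functional assay on cells (Homo sapiens) for antiproliferative activity, read by MTT assay, with a stated time of 48 h (on this read-out higher numbers stand for weaker inhibition and lower numbers for stronger inhibition), compound 1 `CN(C)CCn1c(N)c(-c2nc3ccccc3[nH]2)c2nc(C#N)c(C#N)nc21` gives 43500 nM. Compound 2 `CN(C)CCn1c(N)c(-c2nc3ccccc3n2C)c2nc(C#N)c(C#N)nc21` reads > 50000 nM, which is a limit of the assay and not a number. Compound 2 therefore has no exact place on the scale: the limit of > 50000 nM in this assay, at which 1 of the 2 values shown sits. For the measured compounds named here, the one measured step, an at least 1.1-fold higher number from compound 1 to compound 2 (0.06 log units; that floor lies within the scatter), is methyl in place of hydrogen on an aromatic nitrogen, and it gives only a floor within the scatter.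

Compound 3 `CN(C)CCCCn1c(N)c(-c2nc3ccccc3n2C)c2nc(C#N)c(C#N)nc21` keeps that methyl and changes the side chain: 2-(dimethylamino)ethyl in place of dimethylamino on a saturated chain carbon, two bonds along the chain from an aromatic nitrogen. Going by the values given here, no measured step touches this chain, so no direct size can be taken from the data. Among the compounds with values here, the only guide is the level of the series, with compound 1 at 43500 nM. No step beyond the scatter is therefore expected in this assay, with at most a slight lean towards lower numbers. The estimate is an at least 1.2-fold lower number from compound 2 to compound 3 (0.09 log units; that floor lies within the scatter). For compound 3 the expected value is 40000 nM, within an estimated range of 12000 nM to 50000 nM.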

Compound 3, half-maximal inhibitory concentration: 1790 nM
The estimate for compound 3 lay 22-fold (1.35 log units) above the measured number, and the stated range ends above it.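

In this assay, for the compounds shown here, the chain on the aromatic nitrogen is the first place where a change moves the read-out beyond the scatter: 2-(dimethylamino)ethyl in place of dimethylamino on a saturated chain carbon, two bonds along the chain from an aromatic nitrogen, gives an at least 27-fold lower number from compound 2 to compound 3 (1.44 log units; beyond the scatter). The only earlier step, methyl in place of hydrogen on an aromatic nitrogen, gave an at least 1.1-fold higher number from compound 1 to compound 2 (0.06 log units; that floor lies within the scatter), and among the compounds shown, the chain is therefore the one place with a step clearly beyond the scatter. The new step is itself only a floor, and the value of compound 2 is a limit of the assay, not a number: the limit of > 50000 nM in this assay, at which 1 of the 3 values shown sits.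

On these data alone, whether the 4-(dimethylamino)butyl chain keeps this level with hydrogen in place of the methyl on the aromatic nitrogen stays open. Also open, as far as these compounds go, is how the intermediate 3-(dimethylamino)propyl chain, a chain longer than 4-(dimethylamino)butyl, or a piperidine in place of dimethylamino would read.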